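Chloro added beside fluoro on the pyrazolone aryl ring

A few compounds are considered here, and "the series" means these few. Any claim that something is new, unique, unknown or untested is made for them only; others in the source may bear on it.

Three compounds share a core in which an amide links a pyridazinone-type acid to a fluorinated anilino ether. Compound 1 `Cc1cc(=O)n(-c2cccc(F)c2)nc1C(=O)Nc1ccc(Oc2ncnc3ccsc23)c(F)c1` in a functional assay on MCF7 cells (Homo sapiens) for cytotoxicity, read by MTT assay, with a stated time of 72 h (a lower number here means a stronger inhibitor, a higher number a weaker inhibitor), gives 9050 nM. Compound 2 `Cc1cc(=O)n(-c2ccc(F)c(F)c2)nc1C(=O)Nc1ccc(Oc2ncnc3ccsc23)c(F)c1` gives 6900 nM; the change a 1.3-fold lower number from compound 1 to compound 2 (0.12 log units; within the scatter) does not leave the scatter. Compound 3 `O=C(Nc1ccc(Oc2ncnc3ccsc23)c(F)c1)c1nn(-c2ccc(F)cc2)ccc1=O` gives 5720 nM; its number sits inside the scatter of both compound 2 and compound 1, so the three values cannot be told apart on these data.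

Compound 4 `O=C(Nc1ccc(Oc2ncnc3ccsc23)c(F)c1)c1nn(-c2ccc(F)c(Cl)c2)ccc1=O` differs from compound 3 only by chloro in place of hydrogen on an aromatic carbon. Among the measured compounds shown here, the only measured step that bears on this is the addition of a halogen to the same aryl ring, from compound 1 to compound 2, which stayed within the scatter. A second halogen on this ring is therefore expected to change the number little, if at all; a small move toward a lower number is plausible, but nothing beyond the scatter is expected, and the step of a 1.3-fold lower number from compound 3 to compound 4 (0.10 log units; within the scatter) is the estimated size. Compound 4 is expected to give 4500 nM in this assay, with a range of 1800 nM to 11000 nM.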

Compound 4, half-maximal inhibitory concentration: 6630 nM
For compound 4 the middle estimate is 1.5-fold (0.17 log units) below the measured one; measured number inside the range.
By their numbers in this assay, from the lowest: compounds 3, 4, 2 and 1 (each within the scatter of the next).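

Working from the 4-fluorophenyl to the 3-chloro-4-fluorophenyl compound in this assay, the step reads a 1.2-fold higher number from compound 3 to compound 4 (0.06 log units; within the scatter) and the two numbers cannot be told apart. This position, on an aromatic carbon ortho to a fluoro group, therefore carries a chloro with no measurable consequence for the read-out in this pair. The earlier step of a 1.3-fold lower number from compound 1 to compound 2 (0.12 log units; within the scatter) concerned only a fluoro in the methyl-bearing compounds, so a second halogen type in the compounds without that methyl now also stays within the scatter, and no evidence at hand bears on why this is so.

What the compounds shown leave open is whether a group other than a halogen at this position, such as an amine, a carboxylic acid or a longer chain, would give a step beyond the scatter. As far as these compounds go, the ether-linked end of the shared core also stays the same in all four compounds, so it remains open whether a change there would separate these numbers in this assay where changes on the aryl ring have not.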